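The compounds below may be only part of what the source reports. "The series", "measured", "known", "first", "only" and "open" are said of these compounds alone.

Measured so far:
- compound 1, `Cc1cc(C)cc(NC(=O)COc2cc(C)nc3ccccc23)c1`: 55000 nM
- compound 2, `COc1ccc2nc(C)cc(OCC(=O)Nc3cc(C)ccc3C)c2c1`: 45500 nM
- compound 3, `COc1ccc2nc(C)cc(OCC(=O)Nc3cc(OC)c(OC)c(OC)c3)c2c1`: 34000 nM

The read-out throughout is a physicochemical assay for solubility, in phosphate buffer, measured as kinetic solubility, with a stated time of 1 h, at pH 7.4; a lower number here means a less soluble compound, a higher number a more soluble compound. Compound 2 holds the second highest of the three numbers. Its nearest neighbour is compound 1, whose number is higher but within the scatter; the furthest is compound 3, whose number is lower but also within the scatter. For the measured compounds named here, no ordering of the three can therefore be claimed, and no pair of measured compounds differs in a single place, so no step within the measured set is available to calibrate the next change.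

Compound 4, `COc1ccc2nc(C)cc(OCC(=O)Nc3ccccn3)c2c1`, is the unmeasured member. It departs from compound 2 in one place: pyridin-2-yl in place of 2,5-dimethylphenyl on an amide-type nitrogen. The exchange sits on an amide-type nitrogen whose other neighbour is the carbonyl carbon; the core of compound 2 is otherwise kept.

Going by the values given here, with no measured step to lean on, the expectation for this assay rests on the values of compounds 1 to 3, which all sit close together, and on the nature of the exchange. A step from compound 2 to compound 4 of a 2.0-fold higher number from compound 2 to compound 4 (0.30 log units; within the scatter) is expected, toward a higher number, of a size that may reach beyond the scatter but is not assured to. Compound 4 is estimated at 90000 nM, with a range from 40000 nM to 200000 nM.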

Compound 4, solubility: 29000 nM
Compound 4: the middle estimate sits 3.1-fold (0.49 log units) above what was measured; the measured number lies below the stated range.
By their numbers in this assay, from the lowest: compounds 4, 3, 2 and 1 (each within the scatter of the next).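

In this assay, for the compounds shown here, pyridin-2-yl in place of 2,5-dimethylphenyl on an amide-type nitrogen gives a 1.6-fold lower number from compound 2 to compound 4 (0.20 log units; within the scatter) and this is the first step that can be read at a single place. The exchange takes out a ring of carbon only with 8 heavy atoms and brings in a ring with 1 hetero atom, 6 heavy atoms and 1 hydrogen-bond acceptor, yet compound 2 and compound 4 cannot be told apart in this assay, so this change at this position leaves no readable mark on the number. Nothing measured here offers an explanation for this result.

On these data alone, whether any group on this amide-type nitrogen can carry the number beyond the scatter remains open, and a carboxylic acid, an aminoethyl chain or a morpholine ring in place of pyridin-2-yl would test that. Also open, as far as these compounds go, is whether pyridin-3-yl or pyridin-4-yl would read as pyridin-2-yl does here, and whether the same exchange on the core of compound 1 would give a step of similar size.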